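The source may hold more compounds than are shown below. What is called first, only, known or untested is meant among the compounds shown, and "the series" means these compounds.

Compounds measured so far:
compound 1 (`COc1ccc(Nc2ccc3c(c2)S(=O)(=O)C=C3)cc1`) gives 1220 nM
compound 2 (`O=S1(=O)C=Cc2cccc(Nc3ccc(OC(F)(F)F)cc3)c21`) gives 1570 nM
compound 3 (`COc1cc(Nc2cccc3c2S(=O)(=O)C=C3)cc(OC)c1OC`) gives 950 nM

These values come from a functional assay on A549 cells (Homo sapiens) for antiproliferative activity, read by MTT assay, with a stated time of 72 h; a higher number here means a weaker inhibitor, a lower number a stronger inhibitor. Compound 2 lies within the usual scatter of both compound 1 and compound 3, so the numbers do not separate these three compounds.

Compound 4 (`COc1ccc(Nc2cccc3c2S(=O)(=O)C=C3)cc1`) is compound 2 with methyl in place of trifluoromethyl on an oxygen on an aromatic ring. In other words, trifluoromethoxy becomes methoxy. For the measured compounds named here, no two measured compounds differ in just one place, so the data give no direct size for this change. Methoxy is already present in compound 1 at 1220 nM and in compound 3 at 950 nM and both stay within the scatter of compound 2. On that limited evidence, no step beyond the scatter is expected in this assay. The expected 1.4-fold lower number from compound 2 to compound 4 (0.15 log units; within the scatter) is therefore small. For compound 4 the estimated value is 1100 nM with 500 nM to 2500 nM as the expected range.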

Compound 4, half-maximal inhibitory concentration: 2590 nM
Beside the measured number, compound 4's estimate is 2.4-fold (0.37 log units) below it, and the stated range ends below it.
By their numbers in this assay, from the lowest: compounds 3, 1, 2 and 4 (each within the scatter of the next, the first and the last beyond it).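

In this assay, for the compounds shown here, the first comparison of two compounds that differ in one place gives a 1.6-fold higher number from compound 2 to compound 4 (0.22 log units; within the scatter), for methyl in place of trifluoromethyl on an oxygen on an aromatic ring. Going by these compounds alone, this shows directly that trifluoromethoxy and methoxy are not separated in this assay on this core, so removing the fluorine atoms here produces no step that can be told apart from ordinary repeat variation. No measurement bearing on a possible cause accompanies this result.

From the compounds shown here alone, it remains open whether a longer chain such as ethyl or propyl on this oxygen, or a hydroxyl group or an amine in place of the whole methoxy group, would give a step beyond the scatter. This single pair also cannot show whether the same change would behave alike on a different core.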